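Cytotoxicity notes on the step from compound 1 to compound 3

The source may hold more compounds than are shown below. What is called first, only, known or untested is meant among the compounds shown, and "the series" means these compounds.

Measured compounds:
compound 1, `c1ccc(-c2ccc(Cn3cncc3CNc3ccc(-c4onc5ccccc45)c(-c4ccccc4)c3)cc2)cc1`: > 10000 nM
compound 2, `O=[N+]([O-])c1ccc(Cn2cncc2CNc2cccc(-c3ccccc3)c2)cc1`: 10000 nM

In a toxicity assay on NIH3T3 cells (Mus musculus) for cytotoxicity, read by resazurin assay (on this read-out higher numbers stand for an effect only at larger amounts of compound and lower numbers for an effect already at smaller amounts), compound 1 gives > 10000 nM, which is a limit of the assay and not a number. Compound 2 gives 10000 nM in this assay. Where compound 1 stands is told only by the limit of > 10000 nM in this assay, at which 1 of the 2 values shown sits. Compound 3 (`CNC(=O)c1ccc(NCc2cncn2Cc2ccc(-c3ccccc3)cc2)cc1-c1ccccc1`) is not yet measured; it differs from compound 1 by a group of 4 heavy atoms (2 carbon, 1 nitrogen, 1 oxygen; no ring) in place of a group of 9 heavy atoms (7 carbon, 1 nitrogen, 1 oxygen; one five-membered aromatic ring with 2 hetero atoms, one six-membered aromatic ring of carbon only), on an aromatic carbon. Among the compounds with values here, no measured step connects these two compounds. The change is expected to move the read-out by no more than the usual scatter, as a step of a number no higher from compound 1 to compound 3 (the limit leaves the size open). Compound 3 is therefore estimated at 10000 nM, between 4000 nM and 30000 nM.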

Compound 3, half-maximal effective concentration: > 1000 nM
Compound 3: a limit, no number; the forecaster's own chance of this, stated with the estimate: 60%; the middle value is on the limit's open side.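

In this assay, within the data shown here, compound 1 and compound 3 each carry a limit of the assay and not a number, and no step between them can be read. Left open is whether methylcarbamoyl in compound 3, in place of the larger group of compound 1, moves the read-out at all.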